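From phenyl to 4-methoxyphenyl in compound 3

The source may report more compounds than this note shows. Statements on the series, on what has been measured and on what is new or still open speak of the compounds shown alone.

Two close relatives have been tested so far in a functional assay on HepG2 cells (Homo sapiens) for antiproliferative activity, read by MTT assay, with a stated time of 72 h; a lower number here means a stronger inhibitor, a higher number a weaker inhibitor. There, compound 1 `O=C1COc2ccc(-c3cccc(NS(=O)(=O)c4ccc(F)cc4)c3)cc2N1c1ccc(Cl)cc1` gives 27800 nM, and compound 2 `O=C1COc2ccc(-c3cccc(NS(=O)(=O)c4ccc(F)cc4)c3)cc2N1c1ccccc1` gives 30300 nM. These two numbers lie within the scatter of each other, so compound 2 shares its place with compound 1 and neither can be ranked ahead of the other.

The next compound, compound 3 `COc1ccc(N2C(=O)COc3ccc(-c4cccc(NS(=O)(=O)c5ccc(F)cc5)c4)cc32)cc1`, keeps the core of compound 2 and differs in one place: methoxy in place of hydrogen on an aromatic carbon. Methoxy stands in place of hydrogen on an aromatic carbon, which turns phenyl into 4-methoxyphenyl.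

Among the compounds with values here, only one measured step bears on this change: a 1.1-fold higher number from compound 1 to compound 2 (0.04 log units; within the scatter). There, hydrogen stands in place of chloro on an aromatic carbon. It involves a different group, so it is a thin guide for methoxy, but it offers no sign of a large effect. Going by that step alone, no shift beyond the scatter is expected in this assay. The estimated step is a 1.1-fold lower number from compound 2 to compound 3 (0.03 log units; within the scatter). Compound 3 is therefore expected at about 28000 nM, with an estimated range from 14000 nM to 56000 nM.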

Compound 3, half-maximal inhibitory concentration: 29800 nM
For compound 3 the middle estimate is 1.1-fold (0.03 log units) below the measured one; the measured number falls inside the stated range.
By their numbers in this assay, from the lowest: compounds 1, 3 and 2 (each within the scatter of the next).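

Methoxy is the first group tested at this spot that adds heavy atoms with an oxygen, a hydrogen-bond acceptor, yet in this assay the step stays small (a 1.0-fold lower number from compound 2 to compound 3 (0.01 log units; within the scatter)). Replacing chloro with methoxy at the same position also gives a small step (a 1.1-fold higher number from compound 1 to compound 3 (0.03 log units; within the scatter)), so hydrogen, chloro and methoxy, on an aromatic carbon para to a large group, all give values within the scatter of one another in these three compounds, and none of the three can be ranked ahead of the others. No measurement is available that would explain why this position tolerates all three groups with so little effect on the number.

As far as these compounds go, whether an amine, a carboxylic acid or a longer chain such as butoxy at this spot would move the number beyond the scatter remains open, since three groups on one ring give only a narrow view of the position. The rest of the molecule is the same in all three compounds, so they also leave open whether a change elsewhere on the shared core would matter more.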